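Bromo to methoxy exchange on two related pairs

A few compounds are considered here, and "the series" means these few. Any claim that something is new, unique, unknown or untested is made for them only; others in the source may bear on it.

The series is compared in a physicochemical assay for lipophilicity; on this read-out lower numbers stand for lower lipophilicity and higher numbers for higher lipophilicity. Compound 1 `N=C(N)Nc1cccc(C(=O)NNC(=O)NC(CC(=O)O)c2ccc(Br)cc2)c1` gives 1.53. Compound 2 `COc1ccc(C(CC(=O)O)NC(=O)NNC(=O)c2cccc(NC(=N)N)c2)cc1` gives 0.58. The two differ in one place: methoxy in place of bromo on an aromatic carbon. That change produced a number 0.95 log units lower from compound 1 to compound 2 (beyond the scatter).

Compound 3 `O=C(O)CC(CC(=O)NNC(=O)CCCCNc1ccccn1)c1ccc(Br)cc1` gives 2.9, the highest of the three measured numbers; its value lies beyond the scatter from those of compound 1 and compound 2. How the core of compound 3 differs from the core of compound 1 is not broken down here; the two differ in more than one place.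

Compound 4 `COc1ccc(C(CC(=O)O)CC(=O)NNC(=O)CCCCNc2ccccn2)cc1` has not yet been measured in this assay. It stands to compound 3 as compound 2 stands to compound 1: methoxy in place of bromo on an aromatic carbon. The place description agrees word for word with that of the first pair, so this is taken as the same change made on a different core. Among the compounds shown this change occurs twice in all, once measured and once not.

Because compound 1 to compound 2 gave a number 0.95 log units lower from compound 1 to compound 2 (beyond the scatter), a step of similar size and direction is expected from compound 3 to compound 4, namely a number 0.95 log units lower from compound 3 to compound 4 (beyond the scatter); the only uncertainty added is that the surrounding core is not the same. On that basis compound 4 is estimated at 1.95 in this assay, with the range 1.5 to 2.4 expected to hold most repeat measurements.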

Compound 4, partition coefficient: 1.94
Estimate against measurement, compound 4: 0.01 log units above, and the stated range covers the measured number.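

In this assay the exchange of bromo for methoxy gave a number 0.96 log units lower from compound 3 to compound 4 (beyond the scatter) on the second core, set against a number 0.95 log units lower from compound 1 to compound 2 (beyond the scatter) on the first, so the two steps run the same way, are close in size and support carrying the change between these two cores. Within the data shown here, this rests on only two pairs, both with the 4-bromophenyl to 4-methoxyphenyl change on an aromatic carbon para to a large group, and it shows neither that the step would hold on a third core nor that it would hold at any other place on the ring. The data shown give no explanation for the size of the step or for its similarity on the two cores.

Open, on these data alone, is whether other groups at the same place, such as chloro, ethoxy or trifluoromethyl, would also give steps that carry over from one core to the other. Also open, as far as these compounds go, is whether the methoxy step would keep its size on a core bearing a methyl ester in place of the carboxylic acid, or on one with a longer chain.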